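The source may report more compounds than this note shows. Statements on the series, on what has been measured and on what is new or still open speak of the compounds shown alone.

Two compounds that share one core and differ only in the group on the aromatic ring have been tested in a functional assay on the whole organism (strain Swiss Albino) for inhibition, with Mus musculus as the target, in the writhing test, at a dose of 100 mg/kg by the intraperitoneal route; a lower number here means less inhibition, a higher number more inhibition at the dose given (going by the name of the read-out). Compound 1, `O=C(O)CCCNC(=O)N/N=C/c1ccc([N+](=O)[O-])cc1`, gives 90%. Compound 2, `O=C(O)CCCNC(=O)N/N=C/c1ccc(Cl)cc1`, gives 68%, the lower of the two numbers. Going by the values given here, the single measured step is a number 22 percentage points lower from compound 1 to compound 2 (beyond the scatter), which shows that exchanging the group at this place can shift the read-out by a modest amount.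

Compound 3, `CN(C)c1ccc(/C=N/NC(=O)NCCCC(=O)O)cc1`, has not yet been measured. Its difference from compound 2 is dimethylamino in place of chloro on an aromatic carbon. Among the compounds with values here, no measured step involves a dimethylamino group, so the only guide is the step from compound 1 to compound 2, and that step tells how large such an exchange can be but not which way a new group will move the number. The expected step for compound 3 is therefore a number 3 percentage points lower from compound 2 to compound 3 (within the scatter), small and uncertain in direction. Compound 3 is estimated at 65% in this assay, with a range from 40% to 88%.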

Compound 3, a percentage reported as inhibition, in the whole organism at one dose (the size of the read-out at that dose, not a potency): 93%
Compound 3: the middle estimate sits 28 percentage points below what was measured; the whole stated range lies below it.
By their numbers in this assay, from the lowest: compound 2; then compounds 1 and 3 (each within the scatter of the next).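

Replacing chloro with dimethylamino on the aromatic carbon gives a number 25 percentage points higher from compound 2 to compound 3 (beyond the scatter) in this assay, so the high number at this position does not belong to nitro alone. Going by these compounds alone, the step of a number 3 percentage points higher from compound 1 to compound 3 (within the scatter) places nitro and dimethylamino level in this test even though they are quite different groups, which leaves compound 2, with chloro, as the one compound that stands apart, with the lowest number of the three. Nothing measured here bears on what lies behind this pattern.

Within the data shown here, with only three groups at this position, it remains open whether the chloro result is a lone case or part of a wider trend, which a methoxy group, a bromo atom, or a plain hydrogen on the same aromatic carbon would help to show. As far as these compounds go, the other end of the molecule is also open, since all three compounds carry the same carboxylic acid on the same chain, and neither an ester in its place nor a longer chain appears among them.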